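This account rests on a few compounds, and the source may have more. Where it says the series, first, only, none or still open, it means among the compounds named here.

Compound 1 `CSc1nc(NCCCCNc2ccnc3cc(Cl)ccc23)c(C#N)c(-c2ccccc2)n1` and compound 2 `CSc1nc(OCCCNc2ccnc3cc(Cl)ccc23)c(C#N)c(-c2ccccc2)n1` share their core with compound 3 `CSc1nc(-c2ccccc2)c(C#N)c(N2CCN(c3ccnc4cc(Cl)ccc34)CC2)n1` but link the two ends through an open chain rather than through a ring. In an ADME assay on CCRF-CEM cells (Homo sapiens) for inhibition, read by cell counting (a lower number here means a stronger inhibitor, a higher number a weaker inhibitor), compound 1 gives 5200 nM. In this assay compound 2 gives 3300 nM. Compound 3 stands apart: in this assay compound 3 reaches only a limit of the assay, > 250000 nM, and no number is known for it. Where compound 3 stands is therefore described by the limit of > 250000 nM in this assay, at which 1 of the 3 values shown sits, alone.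

Compound 4 `CSc1nc(-c2ccc([N+](=O)[O-])cc2)c(C#N)c(N2CCN(c3ccnc4cc(Cl)ccc34)CC2)n1` differs from compound 3 by nitro in place of hydrogen on an aromatic carbon. Within the data shown here, no measured pair of compounds carries this change, so the expectation for compound 4 rests on compound 3 and its limit. The step of a number no higher from compound 3 to compound 4 (the limit leaves the size open) is expected to be none beyond the scatter, with compound 4 most likely also reported as a limit. For compound 4 the estimate in this assay is 250000 nM, with a range from 50000 nM to 1000000 nM.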

Compound 4, half-maximal inhibitory concentration: 156000 nM
Compound 4: middle estimate off by 1.6-fold (0.20 log units), on the high side; low and high end bracket the measured number.
By their numbers in this assay, from the lowest: compounds 2 and 1 (each within the scatter of the next); then compound 4. At a limit, above all of these: compound 3.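

With nitro in place of hydrogen on an aromatic carbon, para to a large group, compound 4 gives 156000 nM in this assay, the first actual number among the compounds shown that link the two ends through a ring. The change therefore reads as an at least 1.6-fold lower number from compound 3 to compound 4 (0.20 log units; that floor lies within the scatter), and this position carries a nitro group with no rise in the number. Compound 3 remains a limit of the assay, which leaves only a floor for that step: the limit of > 250000 nM in this assay, at which 1 of the 4 values shown sits.

Going by these compounds, how large the true step is stays open, as does whether an amine, a carboxylic acid or a methoxy group at the same place would give a number like that of compound 4. Also open, on these data alone, is whether nitro at this place would shift the open-chain compound 1 and compound 2 in the same way.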